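Methoxy for trifluoromethyl on the aniline of compound 2

The source may report more compounds than this note shows. Statements on the series, on what has been measured and on what is new or still open speak of the compounds shown alone.

Within the data shown here, compound 2 `FC(F)(F)c1ccc(Nc2ccc(N3CC4CC(C3)N4)cn2)cc1` gives 0.818 nM in an assay on HEK293 cells for displacement of a labelled ligand from Neuronal acetylcholine receptor; alpha3/beta4 (Homo sapiens) (a higher number here means a weaker inhibitor, a lower number a stronger inhibitor), the lowest of the three numbers so far, though the gap to compound 3 lies within the scatter. Compound 3 `Fc1ccc(Nc2cncc(N3CC4CC(C3)N4)c2)cc1` gives 1.25 nM in this assay. Compound 1 `COc1ccc(Nc2cncc(N3CC4CC(C3)N4)c2)cc1` gives 2.2 nM, a gap to compound 2 that lies beyond the scatter. Compounds 1 and 3 share a core that differs from the core of compound 2, so neither is a single-change neighbour of compound 2.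

Compound 4 `COc1ccc(Nc2ccc(N3CC4CC(C3)N4)cn2)cc1` differs from compound 2 by methoxy in place of trifluoromethyl on an aromatic carbon. Among the measured compounds shown here, no measured step exchanges these two groups directly. For the measured compounds named here, the only step that bears on the change is a 1.8-fold lower number from compound 1 to compound 3 (0.25 log units; within the scatter), made on the core of compound 1, and it lay within the scatter. Fluoro and trifluoromethyl are not the same group, so this step is only a loose guide, and the core is a different one. For compound 4 the expected step is a 1.8-fold higher number from compound 2 to compound 4 (0.26 log units; within the scatter), which may well fall inside the scatter. The value of compound 4 in this assay is estimated at 1.5 nM, with a range from 0.6 nM to 4 nM.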

Compound 4, inhibition constant: 9.03 nM
For compound 4 the middle estimate is 6.0-fold (0.78 log units) below the measured one; measured number above the stated range.
By their numbers in this assay, from the lowest: compounds 2, 3 and 1 (each within the scatter of the next, the first and the last beyond it); then compound 4.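

In this assay the position para to a large group on the aromatic ring of carbon only proves sensitive on the core of compound 2: methoxy in place of trifluoromethyl gives an 11-fold higher number from compound 2 to compound 4 (1.04 log units; beyond the scatter) and so moves the number well beyond the scatter. Among these compounds, the only earlier step at this position, a 1.8-fold lower number from compound 1 to compound 3 (0.25 log units; within the scatter) on the core of compound 1, exchanged methoxy for fluoro and stayed within the scatter, so it gave no sign of a change of this size, and these compounds cannot separate the part played by the core from the part played by trifluoromethyl as against fluoro. Nothing available here bears on the cause of the large step.

Still open, going by these compounds, is where fluoro would fall on the core of compound 2, a comparison that would show whether the small step on the core of compound 1 carries over to this core. Equally open, on these data alone, is how a nitrile, an amine or a longer chain such as ethoxy would read at this same position, which would show whether methoxy or trifluoromethyl is the exception among groups placed there.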